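Moving the chloro group around the aromatic ring

This account rests on a few compounds, and the source may have more. Where it says the series, first, only, none or still open, it means among the compounds named here.

Compound 1, `COc1ccc(/C=N/NC(=S)NC(C)(C)[C@H]2CC=C(C)CC2)cc1`, gives 47800 nM in a functional assay on NCI-H460 cells (Homo sapiens) for inhibition, read by sulforhodamine B assay, with a stated time of 48 h; on this read-out lower numbers stand for stronger inhibition of growth and higher numbers for weaker inhibition of growth. Compound 2, `CC1=CC[C@H](C(C)(C)NC(=S)N/N=C/c2ccccc2O)CC1`, gives 8400 nM in this assay. Compound 3, `CC1=CC[C@H](C(C)(C)NC(=S)N/N=C/c2ccccc2Cl)CC1`, gives 81000 nM in this assay.

Among these three, compound 3 has the highest number in this assay. Its nearest neighbour is compound 1, separated by a 1.7-fold higher number from compound 1 to compound 3 (0.23 log units; within the scatter), a gap that lies within the scatter of the measurement. Its furthest neighbour is compound 2, separated by a 9.6-fold higher number from compound 2 to compound 3 (0.98 log units; beyond the scatter), a gap that lies beyond the scatter.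

Compound 4, `CC1=CC[C@H](C(C)(C)NC(=S)N/N=C/c2ccc(Cl)cc2)CC1`, differs from compound 3 in one place: 4-chlorophenyl in place of 2-chlorophenyl on a carbon with a double bond to nitrogen. Both carry the same chlorine-bearing aromatic ring, joined to the rest of the molecule through a different ring carbon.

Among the compounds with values here, no measured step shifts a group from one ring position to another, so the bearing of the measured steps is indirect. The step of a 1.7-fold higher number from compound 1 to compound 3 (0.23 log units; within the scatter) exchanges one ring substituent for another on the same carbon and stays within the scatter, while a 9.6-fold higher number from compound 2 to compound 3 (0.98 log units; beyond the scatter) concerns hydroxy against chloro, not position. On this basis the change from compound 3 to compound 4 is expected to give a step of a 1.4-fold lower number from compound 3 to compound 4 (0.13 log units; within the scatter) in this assay, that is, nothing beyond the scatter. Compound 4 is therefore estimated at 60000 nM, with a range from 20000 nM to 180000 nM.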

Compound 4, concentration for total growth inhibition: 21100 nM
Beside the measured number, compound 4's estimate is 2.8-fold (0.45 log units) above it; low and high end bracket the measured number.
By their numbers in this assay, from the lowest: compound 2; then compound 4; then compounds 1 and 3 (each within the scatter of the next).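

In this assay, within the data shown here, the place where the chloro group joins the aromatic ring makes a measurable difference: with the same atoms joined differently, 4-chlorophenyl in place of 2-chlorophenyl gives a 3.8-fold lower number from compound 3 to compound 4 (0.58 log units; beyond the scatter), the first step here that changes position alone. With the ring position held, chloro in place of methoxy now also gives a step beyond the scatter, a 2.3-fold lower number from compound 1 to compound 4 (0.36 log units; beyond the scatter), although 2-chlorophenyl and 4-methoxyphenyl stayed within the scatter of each other, while 4-chlorophenyl still falls short of 2-hydroxyphenyl, a 2.5-fold higher number from compound 2 to compound 4 (0.40 log units; beyond the scatter). Nothing measured here accounts for these differences in growth inhibition.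

Among these compounds, the hydroxy group appears at only one ring position, so it remains open whether moving it would change the number as moving chloro does. From the compounds shown here alone, it is also open whether a bromo group or an amine in place of chloro would show the same dependence on ring position, or whether this pattern would hold on other cell lines.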